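A few compounds are considered here, and "the series" means these few. Any claim that something is new, unique, unknown or untested is made for them only; others in the source may bear on it.

In a functional assay on the whole organism with Rattus norvegicus as the target (on this read-out higher numbers stand for an effect only at larger amounts of compound and lower numbers for an effect already at smaller amounts), three related compounds have been examined. Compound 1 `Cc1cc(C)cc(NN=C2CCC(C)n3c2ncc(C(=O)O)c3=O)c1` reaches only a limit of the assay, > 320 umol/kg. Compound 2 `Cc1cccc(C)c1NN=C1CCC(C)n2c1ncc(C(=O)O)c2=O` gives 320 umol/kg in this assay. Compound 3 `CC1CCC(=NNc2ccc(Cl)c(Cl)c2)c2ncc(C(=O)O)c(=O)n21` also stands at a limit of the assay, > 100 umol/kg, so it sits among the weakest values shown rather than at a firm number. Compound 4 `CC1CCC(=NNc2ccc(Br)cc2Cl)c2ncc(C(=O)O)c(=O)n21` differs from it by 4-bromo-2-chlorophenyl in place of 3,4-dichlorophenyl on an amine nitrogen. Among the compounds with values here, the steps that bear on this change, a number no higher from compound 1 to compound 2 (the limit leaves the size open), a step that the two limits leave unreadable from compound 1 to compound 3 and a step that the limit leaves unreadable from compound 2 to compound 3, each swap the group on an amine nitrogen, and none has a readable size because they run into the limit of > 100 umol/kg in this assay, at which 1 of the 3 values shown sits, and (the limit of > 320 umol/kg in this assay, at which 1 of the 3 values shown sits). No clear direction can therefore be expected in this assay. Compound 4 is expected near 320 umol/kg, between 100 umol/kg and 1000 umol/kg. The step that the limit leaves unreadable from compound 3 to compound 4 is expected to remain within the scatter.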

Compound 4, dose for 50% inhibition: > 100 umol/kg
Compound 4: only a limit was reported; the forecaster's own chance of this, stated with the estimate: 75%; the middle value is on the limit's open side.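

In this assay compound 4 gives only a limit, > 100 umol/kg. Within the data shown here, no step from compound 1, compound 2 or compound 3 to compound 4 can be read. The compounds shown leave open how the group on the amine nitrogen changes the dose needed.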